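Removing the hydroxy group from compound 3

This account rests on a few compounds, and the source may have more. Where it says the series, first, only, none or still open, it means among the compounds named here.

Measured so far in a functional assay on A549 cells (Homo sapiens) for inhibition, read by CCK-8 assay, with a stated time of 72 h, tested at 1 uM; on this read-out higher numbers stand for more inhibition of growth at the one concentration tested and lower numbers for less inhibition of growth:
- compound 1 `CN(C)C(=O)c1cc2cnc(Nc3ccc(NC(=O)C4(C(=O)Nc5ccccc5F)CC4)cc3)nc2n1C1CCCC1` gives 79.1%
- compound 2 `CN(C)C(=O)c1cc2cnc(Nc3ccc(NC(=O)C4(C(=O)Nc5cccc(C#N)c5)CC4)cc3)nc2n1C1CCCC1` gives 70.8%
- compound 3 `CN(C)C(=O)c1cc2cnc(Nc3ccc(NC(=O)C4(C(=O)Nc5ccc(O)cc5)CC4)cc3)nc2n1C1CCCC1` gives 93.6%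

Compound 3 stands highest of the three, and its steps to both others lie beyond the scatter. Compound 4 `CN(C)C(=O)c1cc2cnc(Nc3ccc(NC(=O)C4(C(=O)Nc5ccccc5)CC4)cc3)nc2n1C1CCCC1` is the same molecule without the hydroxy: hydrogen in place of hydroxy on an aromatic carbon (hydrogen in place of hydroxy on an aromatic carbon, so 4-hydroxyphenyl becomes phenyl).

Going by the values given here, all three measured steps swap only this end ring. Two of them lead up to the hydroxy compound and are modest: a number 14.5 percentage points higher from compound 1 to compound 3 (beyond the scatter) and a number 22.8 percentage points higher from compound 2 to compound 3 (beyond the scatter) (both beyond the scatter). The third, a number 8.3 percentage points lower from compound 1 to compound 2 (within the scatter) (within the scatter), suggests that the two compounds without a hydroxy sit close together. Among the compounds with values here, no measured compound carries a plain phenyl, so this comparison is indirect.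

A modest fall in this assay is therefore expected, estimated as a number 13.6 percentage points lower from compound 3 to compound 4 (beyond the scatter) (a forecast only). Compound 4 is expected to give about 80% (estimated range 67% to 92%).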

Compound 4, percent growth inhibition at one concentration: 75%
The estimate for compound 4 lay 5 percentage points above the measured number; the measured number falls inside the stated range.
By their numbers in this assay, from the lowest: compounds 2, 4 and 1 (each within the scatter of the next); then compound 3.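

In this assay, taking away only the hydroxy gives a number 18.6 percentage points lower from compound 3 to compound 4 (beyond the scatter) and so sets the hydroxy compound directly against the bare phenyl ring, rather than against rings carrying other groups. Taking away the cyano gives a number 4.2 percentage points higher from compound 2 to compound 4 (within the scatter) and taking away the fluoro gives a number 4.1 percentage points lower from compound 1 to compound 4 (within the scatter), so neither of these two groups separates from plain hydrogen, and among the four compounds only compound 3 stands apart. Nothing measured here explains what the hydroxy does to raise the number.

The compounds shown leave open whether the hydroxy must sit at this spot on the ring to keep the higher number. They also leave open whether another group there, such as an amine, a methoxy or a carboxylic acid, would match compound 3.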